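Fluorine on the Aromatic Ring: One Change Made Twice

This account rests on a few compounds, and the source may have more. Where it says the series, first, only, none or still open, it means among the compounds named here.

compound 1: `COC1=CC(=O)c2c(c(COC(=O)c3ccccc3F)cn2C)C1=O` — 500 nM
compound 2: `COC1=CC(=O)c2c(c(COC(=O)c3ccccc3)cn2C)C1=O` — 1400 nM
compound 3: `COC1=CC(=O)c2c(c(COc3ccccc3)c(C)n2C)C1=O` — 12000 nM

The three measured compounds were tested in a functional assay on V79-379A cells (Cricetulus griseus) for cytotoxicity, read by MTT assay, in the presence of a further agent that is not named here; on this read-out lower numbers stand for stronger inhibition and higher numbers for weaker inhibition. Compound 1 `COC1=CC(=O)c2c(c(COC(=O)c3ccccc3F)cn2C)C1=O` gives 500 nM, compound 2 `COC1=CC(=O)c2c(c(COC(=O)c3ccccc3)cn2C)C1=O` gives 1400 nM, and compound 3 `COC1=CC(=O)c2c(c(COc3ccccc3)c(C)n2C)C1=O` gives 12000 nM, the highest number of the three. Compound 1 and compound 2 differ only by fluoro in place of hydrogen on an aromatic carbon, and that change gave a 2.8-fold lower number from compound 2 to compound 1 (0.45 log units; beyond the scatter). How the core of compound 3 differs from that of compound 2 is not broken down here.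

Compound 4 `COC1=CC(=O)c2c(c(COc3ccc(F)cc3)c(C)n2C)C1=O` differs from compound 3 by fluoro in place of hydrogen on an aromatic carbon. Within the data shown here, this is the same kind of change as the one from compound 2 to compound 1, but not the same: there the fluorine enters ortho to a large group, here para to a large group, and on a phenoxy rather than an ester. Resting on the step seen in a 2.8-fold lower number from compound 2 to compound 1 (0.45 log units; beyond the scatter), a step of similar direction but less certain size is expected, a 2.0-fold lower number from compound 3 to compound 4 (0.30 log units; within the scatter). Compound 4 is therefore estimated at 6000 nM, within 2000 nM to 18000 nM.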

Compound 4, half-maximal inhibitory concentration: 31000 nM
Compound 4: the middle estimate sits 5.2-fold (0.71 log units) below what was measured; measured number outside the range, above it.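

Placed on the phenoxy compound, fluoro in place of hydrogen gave a 2.6-fold higher number from compound 3 to compound 4 (0.41 log units; beyond the scatter), so the change did not keep its direction from one core to the other. Set side by side, the two steps run opposite ways: the same change on two cores in this assay, a 2.8-fold lower number (0.45 log units; beyond the scatter) from compound 2 to compound 1 and a 2.6-fold higher number (0.41 log units; beyond the scatter) from compound 3 to compound 4, 7.2-fold (0.86 log units) apart, beyond the scatter of two such steps

This shows that, in this series, the step on one core cannot be taken as a guide to the step on the other, but it does not show why, since the two pairs differ at once in the core, in ester versus phenoxy, and in where the fluorine sits.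

The compounds shown leave open whether fluoro placed alike on both the ester and the phenoxy compounds would give matching steps. They also leave open whether chloro, methoxy or an amine on that ring would follow either step.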